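This account rests on a few compounds, and the source may have more. Where it says the series, first, only, none or still open, it means among the compounds named here.

Measured so far:
- compound 1 `O=C(CN1CCN(c2cccc(Cl)c2)CC1)N1CCN(c2nnc(-c3ccccc3)c(-c3ccccc3)n2)CC1` gives 178000 nM in an ADME assay on NIH3T3 cells (Mus musculus) for cytotoxicity, read by MTT assay, with a stated time of 24 h; on this read-out lower numbers stand for stronger inhibition and higher numbers for weaker inhibition.
- compound 2 `COc1ccccc1N1CCN(CC(=O)N2CCN(c3nnc(-c4ccc(C)cc4)c(-c4ccc(C)cc4)n3)CC2)CC1` gives 133000 nM in this assay.

Compound 2 stands alongside compound 1 within the usual scatter of this assay, so the two numbers cannot be told apart. Compound 3 `Cc1ccc(-c2nnc(N3CCN(C(=O)CN4CCN(c5cccc(Cl)c5)CC4)CC3)nc2-c2ccc(C)cc2)cc1` arises from compound 2 by 3-chlorophenyl in place of 2-methoxyphenyl on an amine nitrogen in a ring. Among the measured compounds shown here, no step between two measured compounds differing in one place is available here. Compound 1 already carries the 3-chlorophenyl group on a ring nitrogen and lands close to compound 2, so little movement is expected. Compound 3 is expected to give 150000 nM in this assay, within a range of 75000 nM to 300000 nM. The expected step of a 1.1-fold higher number from compound 2 to compound 3 (0.05 log units; within the scatter) is estimated to stay within the scatter.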

Compound 3, half-maximal inhibitory concentration: 859000 nM
Estimate against measurement, compound 3: 5.7-fold (0.76 log units) below; the whole stated range lies below it.
By their numbers in this assay, from the lowest: compounds 2 and 1 (each within the scatter of the next); then compound 3.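

With 3-chlorophenyl in place of 2-methoxyphenyl on this amine nitrogen in a ring, this assay gives a 6.5-fold higher number from compound 2 to compound 3 (0.81 log units; beyond the scatter), so this position can shift the number beyond the scatter, towards weaker inhibition. Compound 1 and compound 2 differ in more than one place, so they could not show this on their own. Nothing available explains the size of this step. On these data alone, whether a plain phenyl or a 2-chlorophenyl at this nitrogen would land nearer compound 2 or compound 3 remains open, as does whether a 2-methoxyphenyl here would cause a similar shift on the core of compound 1.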